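Swapping Trifluoromethyl for Methyl: What to Expect of Compound 4

This account rests on a few compounds, and the source may have more. Where it says the series, first, only, none or still open, it means among the compounds named here.

The measured compounds and their values:

compound 1, `O=C(/C=C/c1ccc(OCCO)c(OCCO)c1)NCCn1c(C(F)(F)F)cc2ccccc21`: 260 nM
compound 2, `Cc1cc(/C=C/C(=O)NCCn2c(C(F)(F)F)cc3ccccc32)cc(C)c1F`: 306 nM
compound 3, `Cc1cc2ccccc2n1CCNC(=O)/C=C/c1ccc(OCCO)c(OCCO)c1`: 11.4 nM

All three were tested in an assay on C6 cells for antagonist activity at prostaglandin E2 receptor EP2 subtype (Homo sapiens), read by TR-FRET, with stated times of 10 min and 40 min, tested at 1 uM; on this read-out higher numbers stand for weaker inhibition and lower numbers for stronger inhibition. Compound 1 and compound 3 share the same chain and the same substituted aromatic ring at the far end, and differ in one place only: methyl in place of trifluoromethyl on an aromatic carbon. This single change gave a 23-fold lower number from compound 1 to compound 3 (1.36 log units; beyond the scatter), so compound 3 is the most potent of the three measured compounds.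

Compound 2 keeps the trifluoromethyl-bearing core of compound 1 but carries a different aromatic ring at the far end; the difference between the two cores is not broken down here. In this assay compound 2 and compound 1 give numbers that lie within the usual scatter of each other, so no order between them can be read.

Compound 4, `Cc1cc(/C=C/C(=O)NCCn2c(C)cc3ccccc32)cc(C)c1F`, has not yet been measured. It stands to compound 2 exactly as compound 3 stands to compound 1: methyl in place of trifluoromethyl on an aromatic carbon. The place of the change is the same, word for word, in both pairs, so this is the same change made on a different far-end ring.

The step from compound 2 to compound 4 is expected to be of similar size, a 20-fold lower number from compound 2 to compound 4 (1.31 log units; beyond the scatter), an expectation that rests on the earlier step of a 23-fold lower number from compound 1 to compound 3 (1.36 log units; beyond the scatter). Among the measured compounds shown here, since only one example of the change is available, the range is kept wide. Compound 4 is therefore estimated at 15 nM in this assay, expected to fall between 5 nM and 50 nM.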

Compound 4, antagonist equilibrium constant: 3.4 nM
Estimate against measurement, compound 4: 4.4-fold (0.64 log units) above, outside the stated range (below it).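

In this assay, methyl in place of trifluoromethyl again brings a large drop, with a 90-fold lower number from compound 2 to compound 4 (1.95 log units; beyond the scatter), so the direction of the change held when it was carried from one far-end ring to the other. The size of the step did not carry over unchanged, since the two steps lie further apart than repeated measurements would explain: the same change on two cores in this assay, a 23-fold lower number (1.36 log units; beyond the scatter) from compound 1 to compound 3 and a 90-fold lower number (1.95 log units; beyond the scatter) from compound 2 to compound 4, 3.9-fold (0.60 log units) apart, beyond the scatter of two such steps. A step measured on one core can therefore point the right way on another core in this series without fixing how large the step will be there, but two pairs make no general rule, and they do not show why the larger step came with the ring of compound 4.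

Among the compounds shown, only methyl and trifluoromethyl occupy this place on the five-membered ring, so it stays open how an ethyl group, a chlorine atom or a nitrile there would compare. As far as these compounds go, it also stays open whether the same swap would keep its direction and size on a far-end ring carrying an amine or a carboxylic acid, or with a longer chain joining the two ends of the molecule.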